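Dichlorophenyl urea on the tert-butylanilino core

The source may report more compounds than this note shows. Statements on the series, on what has been measured and on what is new or still open speak of the compounds shown alone.

Measured compounds:
compound 1 `COc1cc(NC(=O)Nc2cc(Nc3ccc(C(C)(C)C)cc3)ncn2)cc(OC)c1` gives 32.7% in a functional assay on HCC827 cells (Homo sapiens) for inhibition, read by MTT assay, with a stated time of 48 h, tested at 10 uM; on this read-out higher numbers stand for more inhibition at the one concentration tested (going by the name of the read-out) and lower numbers for less inhibition
compound 2 `COc1ccc(F)cc1Nc1cc(NC(=O)Nc2c(Cl)cccc2Cl)ncn1` gives 78% in this assay
compound 3 `COc1cc(NC(=O)Nc2cc(Nc3cc(F)ccc3OC)ncn2)cc(OC)c1` gives 59% in this assay

Compound 1 is the lowest of the three; compound 3 sits higher by a number 26.3 percentage points higher from compound 1 to compound 3 (beyond the scatter), and compound 2 higher still. The change between compound 3 and compound 2 is 2,6-dichlorophenyl in place of 3,5-dimethoxyphenyl on an amide-type nitrogen, and it gave a number 19 percentage points higher from compound 3 to compound 2 (beyond the scatter).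

Compound 4 `CC(C)(C)c1ccc(Nc2cc(NC(=O)Nc3c(Cl)cccc3Cl)ncn2)cc1` is not yet measured. It differs from compound 1 by 2,6-dichlorophenyl in place of 3,5-dimethoxyphenyl on an amide-type nitrogen. The place is described in the same words for both pairs, so this is the same change, made twice among these compounds. The two cores on which it is made differ by 4-(tert-butyl)phenyl in place of 5-fluoro-2-methoxyphenyl on a nitrogen on an aromatic ring.

Among the measured compounds shown here, for compound 1 to compound 4 a step of about the same size is expected, a number 17.3 percentage points higher from compound 1 to compound 4 (beyond the scatter), because the one earlier instance gave a number 19 percentage points higher from compound 3 to compound 2 (beyond the scatter). For the measured compounds named here, since only one instance of the change is known and it was made on a different core, the range is kept broad. Compound 4 is estimated at 50% in this assay, expected to fall between 32% and 68%.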

Compound 4, a percentage reported as inhibition, at one concentration (the size of the read-out at that concentration, not a potency): 42.3%
Compound 4: the middle estimate sits 7.7 percentage points above what was measured, and the stated range covers the measured number.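

On the core of compound 1, 2,6-dichlorophenyl in place of 3,5-dimethoxyphenyl on the amide-type nitrogen gives a number 9.6 percentage points higher from compound 1 to compound 4 (within the scatter) in this assay, so this step alone does not separate the two compounds. Set beside the earlier instance of the same change, this step does not differ from it by more than repeated measurements would allow: the same change on two cores in this assay, a number 19 percentage points higher (beyond the scatter) from compound 3 to compound 2 and a number 9.6 percentage points higher (within the scatter) from compound 1 to compound 4, 9.4 percentage points apart, within the scatter of two such steps This agrees with the change carrying from one core to the other, but it does not establish that it does, since there are only two instances, one of them within the scatter, and neither says what the step would be on any other core.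

The compounds shown leave open how a group such as an amine-bearing chain or a carboxylic acid would read on the amide-type nitrogen in place of either aryl group. Readings at a single concentration also leave open how these compounds would rank by potency.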